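The compounds below may be only part of what the source reports. "The series", "measured", "known", "first", "only" and "open" are said of these compounds alone.

Two compounds have so far been measured in a functional assay on HeLa cells (Homo sapiens) for inhibition, read by MTT assay, with a stated time of 72 h; a lower number here means a stronger inhibitor, a higher number a weaker inhibitor:

compound 1 `COc1cccc(Nc2nc(Oc3cccc(NC(=O)/C=C/C(C)C)c3)c3sccc3n2)c1`, giving 27000 nM
compound 2 `CCC/C=C/C(=O)Nc1cccc(Oc2nc(Nc3cccc(OC)c3)nc3ccsc23)c1`, giving 7730 nM

Compound 1 stands highest of these two numbers, so it is the weaker inhibitor of the pair; the step of a 3.5-fold lower number from compound 1 to compound 2 (0.54 log units; beyond the scatter) comes from propyl in place of isopropyl on a double-bonded chain carbon. Compound 3 `COc1ccc(Nc2nc(Oc3cccc(NC(=O)/C=C/C(C)C)c3)c3sccc3n2)cn1` has not yet been measured. It differs from compound 1 at a different spot: 6-methoxypyridin-3-yl in place of 3-methoxyphenyl on a nitrogen on an aromatic ring. Among the measured compounds shown here, the one measured step concerns the chain on the other side of the shared core and leaves this ring untouched, so it offers no guide to the direction of the present change, and there is no second ring variation to compare with. With nothing to lean on, the change expected is no change at the digits printed from compound 1 to compound 3 (within the scatter), that is, nothing beyond the scatter. Compound 3 is therefore estimated at 27000 nM, with a range from 9000 nM to 80000 nM.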

Compound 3, half-maximal inhibitory concentration: > 50000 nM
Compound 3: a limit, no number (the forecaster's own chance of this, stated with the estimate: 10%); middle value at least 1.8-fold (0.26 log units) from the limit.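

In this assay compound 3 gives > 50000 nM, which is a limit of the assay and not a number. As far as these compounds go, putting 6-methoxypyridin-3-yl in place of 3-methoxyphenyl on a nitrogen on an aromatic ring gives an at least 1.8-fold higher number from compound 1 to compound 3 (0.26 log units; that floor lies within the scatter), so this change brings no gain in this assay, while the true size of the step remains unknown. Unlike the step between compound 1 and compound 2, this one touches the ring on the nitrogen, and it yields only a floor: the limit of > 50000 nM in this assay, at which 1 of the 3 values shown sits.

The compounds shown leave open whether a phenyl ring carrying an amine or a carboxylic acid in place of the methoxy group would give a lower number at this position. They also leave open whether the same ring change would act alike on the chain of compound 2.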